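The compounds below may be only part of what the source reports. "The series", "measured", "known", "first", "only" and "open" are said of these compounds alone.

Compound 1 `CCNCCNC(=O)c1cc(Cl)c(N)cc1OC`: > 30 mg/kg, a limit of the assay and not a number
Compound 2 `CCC1c2ccccc2CN1CNC(=O)c1cc(Cl)c(N)cc1OC`: 1 mg/kg
Compound 3 `CCCNc1cc(OC)c(C(=O)NC2CCN(Cc3ccccc3)C2)cc1Cl`: 17 mg/kg

All three entries come from a functional assay on the whole organism with Rattus norvegicus as the target; a lower number here means that less compound is needed, a higher number that more compound is needed for the effect. Compound 3, at 17 mg/kg, has the higher of the two true numbers. Compound 2 reads 1 mg/kg, and that gap lies beyond the scatter. The two compounds differ in more than one place, so the gap cannot be tied to any single group.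

The next compound is compound 4 `COc1cc(N(C)C(=O)C(F)(F)F)c(Cl)cc1C(=O)NC1CCN(Cc2ccccc2)C1`. It keeps everything in compound 3 except one group: methyl((trifluoromethyl)carbonyl)amino in place of propylamino on an aromatic carbon, ortho to a chloro group (methyl((trifluoromethyl)carbonyl)amino in place of propylamino on an aromatic carbon). The new group has lost the hydrogen-bond donor of the old one and is about twice its size in heavy atoms.

Going by the values given here, no measured pair in this small set shows what a change at this place does. The direction is therefore open, and no step beyond the scatter is the most cautious expectation. The expected change is a 1.2-fold higher number from compound 3 to compound 4 (0.07 log units; within the scatter). The uncertainty is large, and the assay may report only a limit for compound 4. For compound 4 the estimated value is 20 mg/kg, with an expected range of 4 mg/kg to 70 mg/kg.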

Compound 4, dose for half-maximal effect: 0.3 mg/kg
Estimate against measurement, compound 4: 67-fold (1.82 log units) above; measured number outside the range, below it.
By their numbers in this assay, from the lowest: compound 4; then compound 2; then compound 3. At a limit, above all of these: compound 1.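

In this assay, putting methyl((trifluoromethyl)carbonyl)amino in place of propylamino on the aromatic carbon ortho to a chloro group gives a 57-fold lower number from compound 3 to compound 4 (1.75 log units; beyond the scatter), so this place on the shared core clearly matters for the dose needed. Going by these compounds alone, this is the first measured pair to show that, and the direction is informative: the larger group has no hydrogen-bond donor, yet less compound is needed, so in this pair neither the donor of propylamino nor a small group at this place is required for a low dose. Nothing measured here explains the size or direction of this step.

The change replaces the whole group at once, altering the chain, the amine hydrogen, the carbonyl and the trifluoromethyl together, and the compounds shown do not separate these parts. Open questions are whether a simple methylamino group would retain this low dose, whether an acetyl(methyl)amino group, which keeps the carbonyl but has no fluorine, would do the same, and whether the same swap would give a comparable step on the other amide side chains shown.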